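The source may report more compounds than this note shows. Statements on the series, on what has been measured and on what is new or still open speak of the compounds shown alone.

Among the compounds with values here, in a functional assay on OE33 cells (Homo sapiens) for antiproliferative activity, with a stated time of 72 h (a lower number here means a stronger inhibitor of growth, a higher number a weaker inhibitor of growth), compound 1 (`CN(C)c1cccc2c(S(=O)(=O)N(CC(=O)NCc3ccccc3)Cc3ccc(C(=O)NO)cc3)cccc12`) gives 6230 nM and holds the higher of the two numbers measured so far, which makes it the weaker growth inhibitor of the pair. Compound 2 (`CN(C)c1cccc2c(S(=O)(=O)N(CCCCCC(=O)NO)CC(=O)NCc3ccccc3)cccc12`) reaches 776 nM there. Within the data shown here, the only measured step is an 8.0-fold lower number from compound 1 to compound 2 (0.90 log units; beyond the scatter) and it alters the chain carrying the hydroxycarbamoyl group while leaving that group in place. Compound 3 (`CN(C)c1cccc2c(S(=O)(=O)N(CC(=O)NCc3ccccc3)Cc3ccc(C(=O)Nc4ccccc4N)cc3)cccc12`) keeps the chain of compound 1 and changes the group itself: hydroxycarbamoyl becomes (2-aminophenyl)carbamoyl, that is, 2-aminophenyl in place of hydroxy on an amide-type nitrogen. Among the measured compounds shown here, no measured step covers this swap, so the step to compound 2 shows only how far a number in this small set can move. With the value of compound 1 at 6230 nM as the only anchor, no shift beyond the scatter is expected, although the uncertainty is wide in both directions. The expected result is a small estimated step (a 1.1-fold higher number from compound 1 to compound 3 (0.05 log units; within the scatter)). Compound 3 is estimated at 7000 nM and expected to fall in the range (2000 nM to 25000 nM).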

Compound 3, concentration for 50% growth inhibition: 4590 nM
For compound 3 the middle estimate is 1.5-fold (0.18 log units) above the measured one; measured number inside the range.
By their numbers in this assay, from the lowest: compound 2; then compounds 3 and 1 (each within the scatter of the next).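

In this assay, putting 2-aminophenyl in place of hydroxy on the amide-type nitrogen gives a 1.4-fold lower number from compound 1 to compound 3 (0.13 log units; within the scatter), so compound 1 and compound 3 cannot be told apart. The earlier step altered only the chain carrying the hydroxycarbamoyl group, whereas this one alters the group itself and shows that, on the chain of compound 1, (2-aminophenyl)carbamoyl can stand in place of hydroxycarbamoyl with no change beyond the scatter, even though the entering group brings a six-membered aromatic ring where the leaving hydroxy has none. Nothing measured here bears on why the two numbers stay so close.

Within the data shown here, the result comes from a single chain, so it remains open whether the same swap would read the same way on the saturated chain of compound 2, which gives 776 nM and is the only compound here with a number beyond the scatter of the others. As far as these compounds go, it also remains open how a simpler end group at this place, such as a carboxylic acid or an unsubstituted phenyl amide without the amino group, would compare with hydroxycarbamoyl and (2-aminophenyl)carbamoyl.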